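Replacing a chloroaryl group with a hexyl chain on a benzotriazine di-N-oxide

The compounds below may be only part of what the source reports. "The series", "measured", "known", "first", "only" and "open" are said of these compounds alone.

The measured compounds and their values:
Compound 1, `CCCOCNc1n[n+]([O-])c2cc(OC)ccc2[n+]1[O-]`: 6570 nM
Compound 2, `O=[N+]([O-])c1cccc(COCNc2n[n+]([O-])c3ccccc3[n+]2[O-])c1`: 3070 nM
Compound 3, `[O-][n+]1nc(NCOCc2ccc(Cl)cc2)[n+]([O-])c2ccccc21`: 5760 nM

In a functional assay on PC-3 cells (Homo sapiens) for cytotoxicity, read by MTT assay, with a stated time of 72 h (on this read-out higher numbers stand for weaker inhibition and lower numbers for stronger inhibition), compound 3 has the second highest of the three numbers. Its nearest neighbour is compound 1, and both of its gaps, to compound 1 and to compound 2, lie within the usual scatter of repeated measurements, so the three compounds cannot be told apart on these numbers.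

Compound 4, `CCCCCCCOCNc1n[n+]([O-])c2ccccc2[n+]1[O-]`, has not yet been measured. Compared with compound 3 the change is hexyl in place of 4-chlorophenyl on a saturated chain carbon bound to an oxygen on a saturated carbon. Going by the values given here, no pair of measured compounds shows this kind of change, so no measured step guides the expectation. Given that the three measured compounds all sit close together, the step in this assay is expected to stay within the scatter, with no clear direction, as a 1.2-fold higher number from compound 3 to compound 4 (0.08 log units; within the scatter). Compound 4 is therefore estimated at 7000 nM, in a range from 3000 nM to 16000 nM.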

Compound 4, half-maximal inhibitory concentration: 1210 nM
Estimate against measurement, compound 4: 5.8-fold (0.76 log units) above; measured number outside the range, below it.
By their numbers in this assay, from the lowest: compound 4; then compounds 2, 3 and 1 (each within the scatter of the next, the first and the last beyond it).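

In this assay, this place, on a saturated chain carbon bound to an oxygen on a saturated carbon, proves sensitive to the group it carries: hexyl in place of 4-chlorophenyl gives a 4.8-fold lower number from compound 3 to compound 4 (0.68 log units; beyond the scatter). The earlier compounds shown here offered no single-place step, and this one shows that an aromatic ring is not required here. Nothing shown explains the step.

A plain phenyl group would separate the loss of chlorine from the loss of the ring. Going by these compounds, whether a longer chain, such as decyl, or a chain ending in an amine continues the trend remains open.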